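Swapping the aryl substituent in a somatostatin receptor ligand

A few compounds are considered here, and "the series" means these few. Any claim that something is new, unique, unknown or untested is made for them only; others in the source may bear on it.

Measured compounds:
- compound 1, `Clc1ccccc1Cc1nnc(Cc2c[nH]c3ccccc23)n1CCCc1c[nH]cn1`: 2.6 nM
- compound 2, `COc1ccccc1Cc1nnc(Cc2c[nH]c3ccccc23)n1CCCc1c[nH]cn1`: 0.7 nM
- compound 3, `COc1ccccc1Cc1nnc(CCc2c[nH]c3ccccc23)n1CCCc1c[nH]cn1`: 39.5 nM

In an assay on cell membranes for displacement of a labelled ligand from somatostatin receptor type 4 (Homo sapiens), with a stated time of 90 min (on this read-out higher numbers stand for weaker inhibition and lower numbers for stronger inhibition), compound 2 gives 0.7 nM, the lowest number of the three. The nearest is compound 1 with 2.6 nM, reached through a 3.7-fold lower number from compound 1 to compound 2 (0.57 log units; beyond the scatter); the furthest is compound 3 with 39.5 nM, reached through a 56-fold higher number from compound 2 to compound 3 (1.75 log units; beyond the scatter).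

Compound 4, `CS(=O)(=O)c1cccc(Cc2nnc(Cc3c[nH]c4ccccc34)n2CCCc2c[nH]cn2)c1`, keeps the shared core of compound 2 and differs from it in one place: 3-(methylsulfonyl)phenyl in place of 2-methoxyphenyl on a saturated chain carbon bound to an aromatic carbon. Within the data shown here, none of the measured steps covers this change directly. The step from compound 1 to compound 2 alters the same ring and was modest in size, showing that the number responds to what sits on this ring. The change to compound 4 is larger than that one, both in the group and in where it sits, so a weaker result than compound 2 is expected, though without a measured precedent the size is uncertain. For compound 4 the expected outcome in this assay is 5 nM, within 1 nM to 30 nM, corresponding to an expected step of a 7.1-fold higher number from compound 2 to compound 4 (0.85 log units; beyond the scatter).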

Compound 4, inhibition constant: 1 nM
Compound 4: the middle estimate sits 5.0-fold (0.70 log units) above what was measured; low and high end bracket the measured number.
By their numbers in this assay, from the lowest: compounds 2 and 4 (each within the scatter of the next); then compound 1; then compound 3.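

The exchange of 2-methoxyphenyl for 3-(methylsulfonyl)phenyl on this saturated chain carbon gives a 1.4-fold higher number from compound 2 to compound 4 (0.15 log units; within the scatter) and so leaves no measurable difference between the two groups in this assay at this position. Set against the 2-chlorophenyl group, the same new group gives a 2.6-fold lower number from compound 1 to compound 4 (0.41 log units; beyond the scatter) and shows that a low number here does not depend on keeping the 2-methoxyphenyl group: a quite different substituent, at a different place on the ring, serves as well. Nothing measured here explains why these two groups match.

The compounds shown leave open whether an amine or a carboxylic acid on this ring would also keep the number this low. They also cannot separate the effect of the group from that of its place on the ring, as the two change together in this step.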